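Furan-to-Isoxazole Swap on an Alpha-1D Agonist Scaffold

The compounds below may be only part of what the source reports. "The series", "measured", "known", "first", "only" and "open" are said of these compounds alone.

Compound 1 `c1coc(-c2ccccc2NCC2=NCCN2)c1` in a functional assay for activation of Alpha-1D adrenergic receptor (Homo sapiens) (a lower number here means that less compound is needed, a higher number that more compound is needed for the effect), gives 16.2 nM.
Compound 2 `Cc1ncc(-c2ccccc2NCC2=NCCN2)o1` in this assay gives only a limit of the assay, < 5020 nM.
Compound 3 `Cc1nc(-c2ccccc2NCC2=NCCN2)cs1` in this assay gives only a limit of the assay, < 5020 nM.

Among the measured compounds shown here, compound 1 stands as the only compound with a read number in this assay, against (the limit of < 5020 nM in this assay, at which 2 of the 3 values shown sit). The steps a step that the limit leaves unreadable from compound 1 to compound 2 and a step that the limit leaves unreadable from compound 1 to compound 3 cannot be sized, and the two limits together leave a step that the two limits leave unreadable from compound 2 to compound 3 unreadable as well.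

Compound 4 `c1ccc(-c2cnoc2)c(NCC2=NCCN2)c1` carries the change (1,2-oxazol-4-yl in place of furan-2-yl on an aromatic carbon). Both measured steps from compound 1 also replace the furan-2-yl with a five-membered aromatic ring holding two hetero atoms, so they are the closest comparisons available, yet neither gives a size, only the information that the replacement compounds sit at a limit of the assay. For the measured compounds named here, no measured step therefore tells how far compound 4 moves in this assay.

With that in mind, compound 4 is expected to lose some potency in this assay, estimated as a 4.9-fold higher number from compound 1 to compound 4 (0.69 log units; beyond the scatter). Compound 4 is estimated at 80 nM, with a wide range from 12 nM to 600 nM.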

Compound 4, half-maximal effective concentration: < 100000 nM
Compound 4 gave a limit, no number; the forecaster's own chance of this, stated with the estimate: 15%; the middle value lies beyond the limit too.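

No new step can be read: compound 4, like compound 2 and compound 3, gives only a limit in this assay, so its steps to compound 1 and to those two compounds cannot be sized. The compounds shown leave open how far 1,2-oxazol-4-yl, or either other replacement for furan-2-yl, shifts the number in this assay.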